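Sulfanylmethyl substituent changes on the shared core

This account rests on a few compounds, and the source may have more. Where it says the series, first, only, none or still open, it means among the compounds named here.

Three analogues sharing one core have been measured in an assay on CHO cells for displacement of a labelled ligand from adenosine receptor A3 (Homo sapiens), read by scintillation counting, with a stated time of 120 min, tested at 1 uM; a higher number here means more inhibition at the concentration tested (going by the name of the read-out), a lower number less inhibition. Compound 1 `N#Cc1c(N)nc(SCc2cccc(C(N)=O)c2)c(C#N)c1-c1ccc(OCC2CC2)cc1` gives 1%, compound 2 `N#Cc1c(N)nc(SCC(N)=O)c(C#N)c1-c1ccc(OCC2CC2)cc1` gives 8%, and compound 3 `CNC(=O)CSc1nc(N)c(C#N)c(-c2ccc(OCC3CC3)cc2)c1C#N` gives 3%. For the measured compounds named here, on these numbers compound 3 stands second highest of the three, nearest to compound 1 and furthest from compound 2, but a number 2 percentage points higher from compound 1 to compound 3 (within the scatter) and a number 5 percentage points lower from compound 2 to compound 3 (within the scatter) both lie within the scatter, so no compound separates from the others.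

Compound 4 `N#Cc1c(N)nc(SCc2cnc[nH]2)c(C#N)c1-c1ccc(OCC2CC2)cc1` has not been measured. It differs from compound 3 in one place: 1H-imidazol-5-yl in place of methylcarbamoyl on a saturated chain carbon bound to a sulfur. Going by the values given here, the steps that bear on this change are those at the same place, a number 7 percentage points higher from compound 1 to compound 2 (within the scatter) and a number 2 percentage points higher from compound 1 to compound 3 (within the scatter), and the amide change a number 5 percentage points lower from compound 2 to compound 3 (within the scatter); all are within the scatter. No step beyond the scatter is therefore expected, and the estimated step is a number 1 percentage points higher from compound 3 to compound 4 (within the scatter). Compound 4 is expected to give about 4% in this assay, within a range from 0% to 14%.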

Compound 4, a percentage reported as inhibition, at one concentration (the size of the read-out at that concentration, not a potency): 1%
Estimate against measurement, compound 4: 3 percentage points above; the measured number falls inside the stated range.
By their numbers in this assay, from the lowest: compounds 1, 4, 3 and 2 (each within the scatter of the next).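

Replacing methylcarbamoyl with 1H-imidazol-5-yl on a saturated chain carbon bound to a sulfur gives a small step in this assay (a number 2 percentage points lower from compound 3 to compound 4 (within the scatter)), and the comparisons with the other two analogues read (a number 7 percentage points lower from compound 2 to compound 4 (within the scatter)) and (no change at the digits printed from compound 1 to compound 4 (within the scatter)). The earlier compounds shown here all carried a carbamoyl-type group at this place, whereas compound 4 has a five-membered aromatic ring with no carbonyl, and still no step leaves the scatter. No supporting data are available to explain this flat response.

As far as these compounds go, whether a carboxylic acid, an amine or a longer chain at this place would give a step beyond the scatter remains open. The compounds shown also leave open whether changes elsewhere on the shared core would alter this picture.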